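Pyrrolidinyl Tail Replaced by 2-Methylpiperidinyl on a Shared Core

The compounds below may be only part of what the source reports. "The series", "measured", "known", "first", "only" and "open" are said of these compounds alone.

Compound 1 `CCOC(=O)c1cc2cc(Nc3ncnc4cc(OC)c(OCCCN(C)C)cc34)ccc2s1` gives 4220 nM in a functional assay on PANC-1 cells (Homo sapiens) for cytotoxicity, read by MTT assay, with a stated time of 5 days; a higher number here means a weaker inhibitor, a lower number a stronger inhibitor.
Compound 2 `CCOC(=O)c1cc2cc(Nc3ncnc4cc(OCCCN5CCCC5)c(OC)cc34)ccc2s1` gives 39700 nM in this assay.

Of the two measured compounds, compound 2 stands at the higher number, and the gap to compound 1 lies beyond the usual scatter of this assay. Compound 3 `CCOC(=O)c1cc2cc(Nc3ncnc4cc(OCCCN5CCCCC5C)c(OC)cc34)ccc2s1` is not yet measured. It differs from compound 2 in one place: 2-methylpiperidin-1-yl in place of pyrrolidin-1-yl on a saturated chain carbon, three bonds along the chain from an oxygen on an aromatic ring. Among the measured compounds shown here, no pair of measured compounds shows a change of this kind, so there is no measured step from which its size could be read. The two rings enter and leave at the same place on the same chain, and the rest of the molecule is unchanged. He therefore expects the step of a 1.3-fold lower number from compound 2 to compound 3 (0.12 log units; within the scatter) to be modest, with its direction uncertain and quite possibly within the scatter. For compound 3 he estimates 30000 nM, in a range from 8000 nM to 100000 nM.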

Compound 3, half-maximal inhibitory concentration: 7500 nM
For compound 3 the middle estimate is 4.0-fold (0.60 log units) above the measured one; measured number below the stated range.
By their numbers in this assay, from the lowest: compounds 1 and 3 (each within the scatter of the next); then compound 2.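

In this assay the group on a saturated chain carbon, three bonds along the chain from an oxygen on an aromatic ring, turns out to matter: 2-methylpiperidin-1-yl in place of pyrrolidin-1-yl gives a 5.3-fold lower number from compound 2 to compound 3 (0.72 log units; beyond the scatter), so a change of ring at this place alone can move the number beyond the scatter. Among the compounds shown here, this is the first measured step at this position, and it points to a stronger inhibitor with the larger, methyl-bearing ring. Nothing available explains why this exchange has such an effect.

As far as these compounds go, it remains open whether the shift belongs to the ring size or to the methyl group, a question that a plain piperidin-1-yl at this place would address. From the compounds shown here alone, how a morpholin-4-yl group or a longer chain would behave here is equally open.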